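Azido to acetamido: the next step in the series

The compounds below may be only part of what the source reports. "The series", "measured", "known", "first", "only" and "open" are said of these compounds alone.

Within the data shown here, in an ADME assay on L6 cells (Rattus norvegicus) for inhibition, read by resazurin assay, with a stated time of 72 h (a higher number here means a weaker inhibitor, a lower number a stronger inhibitor), compound 1 (`C[S+]([O-])C[C@H]1O[C@@H](n2cnc3c(N)nc(F)nc32)[C@H](O)[C@@H]1O`) gives 13000 nM and compound 2 (`[N-]=[N+]=NC[C@H]1O[C@@H](n2cnc3c(N)nc(F)nc32)[C@H](O)[C@@H]1O`) gives 3100 nM, so compound 2 holds the lower of the two numbers so far. The next structure is compound 3 (`CC(=O)NC[C@H]1O[C@@H](n2cnc3c(N)nc(F)nc32)[C@H](O)[C@@H]1O`), with this difference: acetamido in place of azido on a saturated chain carbon bound to a saturated ring carbon. In words, acetamido stands in place of azido on a saturated chain carbon bound to a saturated ring carbon.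

Among the measured compounds shown here, only one measured step bears on this change, and it falls at the same place: a 4.2-fold lower number from compound 1 to compound 2 (0.62 log units; beyond the scatter). It is modest but beyond the scatter. For the measured compounds named here, it shows that this assay responds to a change of group here, but no measurement yet covers acetamido. Going by the values given here, the only non-azido group measured, in compound 1 at 13000 nM, reads higher than azido. A move away from azido is therefore expected to raise the number by a similarly modest amount, with low confidence. The expected step is a 2.9-fold higher number from compound 2 to compound 3 (0.46 log units; beyond the scatter). For compound 3 the estimated value is 9000 nM, with an expected range of 2500 nM to 30000 nM.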

Compound 3, half-maximal inhibitory concentration: 182000 nM
The estimate for compound 3 lay 20-fold (1.31 log units) below the measured number, and the stated range ends below it.
By their numbers in this assay, from the lowest: compound 2; then compound 1; then compound 3.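

In this assay, among these compounds, this saturated chain carbon bound to a saturated ring carbon proves far more sensitive to the group it carries than the first pair could show: azidomethyl to acetamidomethyl gives a 59-fold higher number from compound 2 to compound 3 (1.77 log units; beyond the scatter), whereas the only earlier step was a 4.2-fold lower number from compound 1 to compound 2 (0.62 log units; beyond the scatter). Acetamido also reads well above the group in compound 1, with a 14-fold higher number from compound 1 to compound 3 (1.15 log units; beyond the scatter), so replacing azido does not simply give a similar modest rise, and among these three compounds the choice of group spans a large range of inhibition. Nothing available explains why acetamido gives so much weaker inhibition than azido or the group in compound 1.

The three compounds cannot show whether the loss follows the amide hydrogen, the carbonyl or the added methyl of the acetyl group, and a primary amine, a formamide or an N-methyl acetamide at this place would help separate these parts. Nor can they show whether the large step from azido to acetamido would hold on a core other than the one shared here.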